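The source may hold more compounds than are shown below. What is called first, only, known or untested is meant among the compounds shown, and "the series" means these compounds.

Measured in a functional assay on MCF7 cells (Homo sapiens) for inhibition, read by MTT assay, with a stated time of 48 h; on this read-out lower numbers stand for stronger inhibition and higher numbers for weaker inhibition:
Compound 1 `COc1cc2cc(C(=O)Nc3ccccc3)c(=O)oc2cc1OCCCOc1no[n+]([O-])c1S(=O)(=O)c1ccccc1` gives 740 nM.
Compound 2 `COc1cc2cc(C(=O)NCCCc3ccc(F)cc3)c(=O)oc2cc1OCCCOc1no[n+]([O-])c1S(=O)(=O)c1ccccc1` gives 600 nM.
Compound 3 `COc1cc2cc(C(=O)NCc3ccccc3)c(=O)oc2cc1OCCCOc1no[n+]([O-])c1S(=O)(=O)c1ccccc1` gives 740 nM.

Compound 2 shows the lowest of the three numbers, yet its neighbours sit within the scatter: a 1.2-fold higher number from compound 2 to compound 3 (0.09 log units; within the scatter), and the step from compound 1 is equally small. Compound 4 `COc1cc2cc(C(=O)Nc3ccc(F)cc3)c(=O)oc2cc1OCCCOc1no[n+]([O-])c1S(=O)(=O)c1ccccc1` is not yet measured; it differs from compound 2 by 4-fluorophenyl in place of 3-(4-fluorophenyl)propyl on an amide-type nitrogen. Within the data shown here, two measured steps bear on this change. First, a 1.2-fold lower number from compound 1 to compound 2 (0.09 log units; within the scatter) shows that the 3-(4-fluorophenyl)propyl chain on the amide nitrogen altered little. Second, no change at the digits printed from compound 1 to compound 3 (within the scatter) shows the same for benzyl in place of phenyl. Putting 4-fluorophenyl in place of that chain is therefore expected to give no step beyond the scatter, a 1.2-fold higher number from compound 2 to compound 4 (0.07 log units; within the scatter). Compound 4 is estimated at 700 nM in this assay, between 350 nM and 1400 nM.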

Compound 4, half-maximal inhibitory concentration: 860 nM
The estimate for compound 4 lay 1.2-fold (0.09 log units) below the measured number, and the stated range covers the measured number.
By their numbers in this assay, from the lowest: compounds 2, 1, 3 and 4 (each within the scatter of the next).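

Fluoro in place of hydrogen on an aromatic carbon gives a 1.2-fold higher number from compound 1 to compound 4 (0.07 log units; within the scatter) in this assay and so stays within the scatter. With fluorine on the phenyl ring, 4-fluorophenyl in place of the other groups on the amide-type nitrogen gives a 1.4-fold higher number from compound 2 to compound 4 (0.16 log units; within the scatter) and a 1.2-fold higher number from compound 3 to compound 4 (0.07 log units; within the scatter) and so also stays within it, which means that neither 3-(4-fluorophenyl)propyl nor benzyl stands apart from 4-fluorophenyl here. No supporting data are available to explain these small steps.

On these data alone, whether an amine, a carboxylic acid or a much longer chain on the amide-type nitrogen would move the number beyond the scatter remains open.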